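The source may report more compounds than this note shows. Statements on the series, on what has been measured and on what is new or still open speak of the compounds shown alone.

Compound 1 `N#Cc1c(F)c(Cl)c2nc(N)nc(N)c2c1F` and compound 2 `N#Cc1c(F)c(F)c2nc(N)nc(N)c2c1F` share one core. In a functional assay on A549 cells (Homo sapiens) for cytotoxicity, read by MTT assay (on this read-out lower numbers stand for stronger inhibition and higher numbers for weaker inhibition), compound 1 gives 30.8 ug/mL. The value of compound 2, > 1000 ug/mL, is a limit of the assay, (the limit of > 1000 ug/mL in this assay, at which 1 of the 3 values shown sits). Across the change fluoro in place of chloro on an aromatic carbon the step is an at least 32-fold higher number from compound 1 to compound 2 (1.51 log units; beyond the scatter).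

Compound 3 `CCCCNc1c(C#N)c(NCCCC)c2c(N)nc(N)nc2c1Cl` carries a core whose difference from the core of compound 1 is not broken down here. In this assay compound 3 gives 2 ug/mL, the lowest of the two numbers, with compound 1 the nearest.

Compound 4 `CCCCNc1c(C#N)c(NCCCC)c2c(N)nc(N)nc2c1F` is not yet measured. It differs from compound 3 by fluoro in place of chloro on an aromatic carbon, the same kind of change as from compound 1 to compound 2, but the place differs: in compound 3 the carbon is ortho to a butylamino group and para to a butylamino group, where in compound 1 it is ortho to a fluoro group and para to a fluoro group. Beside the earlier step, a rise is expected from compound 3 to compound 4 of a 15-fold higher number from compound 3 to compound 4 (1.18 log units; beyond the scatter), resting on an at least 32-fold higher number from compound 1 to compound 2 (1.51 log units; beyond the scatter), with the changed surroundings leaving the size open. For compound 4 the estimate in this assay is 30 ug/mL, between 5 ug/mL and 300 ug/mL.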

Compound 4, half-maximal inhibitory concentration: > 1000 ug/mL
Compound 4: no number, only a limit (the forecaster's own chance of this, stated with the estimate: 10%); at least 33-fold (1.52 log units) between middle value and limit.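

In this assay, fluoro in place of chloro on an aromatic carbon gives a higher number on the core of compound 3, as it does on the core of compound 1, with an at least 500-fold higher number from compound 3 to compound 4 (2.69 log units; beyond the scatter). The value of compound 4, > 1000 ug/mL, is a limit and not a number. The direction of the change therefore holds in both pairs, even though the carbon in compound 3 is ortho to a butylamino group and para to a butylamino group, but two pairs establish no rule for the series, and the true size of each step remains unknown, so no difference in size can be claimed: the same change on two cores in this assay, an at least 32-fold higher number (1.51 log units; beyond the scatter) from compound 1 to compound 2 and an at least 500-fold higher number (2.69 log units; beyond the scatter) from compound 3 to compound 4; the limit leaves it open whether they differ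

Going by these compounds, it remains open how the number moves with bromo, methyl or a plain hydrogen on that carbon, which would show whether chloro itself matters or fluoro alone gives the loss. Also open, on these data alone, is how a shorter chain, a longer chain or a cyclic amine in place of butylamino would alter the number on the chloro core.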